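The compounds below may be only part of what the source reports. "The series", "measured", "known", "first", "only" and "open" are said of these compounds alone.

In an assay for binding affinity (a higher number here means weaker binding, a lower number tighter binding), two compounds have been measured so far:

- compound 1 `COc1ccc(C(Sc2ccccc2)c2cccnc2)cc1`: 20000 nM
- compound 2 `COc1ccc(C(Sc2ccccc2C)c2cccnc2)cc1`: 26000 nM

Compound 2 gives 26000 nM, which lies within the usual scatter of the number for compound 1, so the two cannot be ranked. Both are simply weak binders on this scale.

The next compound is compound 3 `COc1ccc(C(Sc2ccc(C)cc2)c2cccnc2)cc1`. It has the same atoms as compound 2, joined differently, with 4-methylphenyl in place of 2-methylphenyl on a sulfur.

Among the compounds with values here, only one measured step bears on this change: a 1.3-fold higher number from compound 1 to compound 2 (0.11 log units; within the scatter). That step introduced the 2-methylphenyl group that now leaves, and it stayed within the scatter. Within the data shown here, no compound carrying 4-methylphenyl has been measured, so this guide is indirect and the range must stay wide. Going by the small size of that single step, no change beyond the scatter is expected in this assay, in either direction. The estimated step is a 1.2-fold lower number from compound 2 to compound 3 (0.07 log units; within the scatter). For compound 3 the expected value is 22000 nM, with an estimated range of 9000 nM to 50000 nM.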

Compound 3, dissociation constant: 12000 nM
Beside the measured number, compound 3's estimate is 1.8-fold (0.26 log units) above it, and the stated range covers the measured number.
By their numbers in this assay, from the lowest: compounds 3, 1 and 2 (each within the scatter of the next, the first and the last beyond it).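

Swapping 2-methylphenyl for 4-methylphenyl on the sulfur gives a 2.2-fold lower number from compound 2 to compound 3 (0.34 log units; beyond the scatter) in this assay, the first step in this short series to pass beyond the scatter, though only modestly. The other new comparison, with the unsubstituted phenyl of compound 1, gives a 1.7-fold lower number from compound 1 to compound 3 (0.22 log units; within the scatter), so neither methyl-bearing compound can be separated from compound 1, and only compound 2 and compound 3 can be told apart. What the earlier pair could not show is that two groups with identical atom counts can give distinguishable numbers at this place, although nothing available explains this difference.

From the compounds shown here alone, it remains open whether other groups on this aromatic ring, such as a chlorine, a methoxy or an amine, would give a larger step than this modest one, or whether they would stay within the scatter like the methyl of compound 2. Going by these compounds, it is also open whether a longer chain such as ethyl would follow the same difference between the 2-substituted and 4-substituted rings, since a single pair of isomers defines no trend.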